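From 4-fluorophenyl to naphthalen-1-yl on a sulfur

The source may report more compounds than this note shows. Statements on the series, on what has been measured and on what is new or still open speak of the compounds shown alone.

Measured so far in a functional assay on SMMC-7721 cells (Homo sapiens) for inhibition, read by CCK-8 assay, with a stated time of 72 h, tested at 2 uM; on this read-out lower numbers stand for less inhibition of growth and higher numbers for more inhibition of growth at the one concentration tested:
- Compound 1 `Nc1ccccc1NC(=O)/C=C/c1ccc(CSc2cccc(F)c2)cc1` gives 8.56%
- Compound 2 `Nc1ccccc1NC(=O)/C=C/c1ccc(CSc2ccc(C(F)(F)F)cn2)cc1` gives 12.1%
- Compound 3 `Nc1ccccc1NC(=O)/C=C/c1ccc(CSc2ccc(F)cc2)cc1` gives 18.3%

Compound 3, at 18.3%, lies within the scatter of both other compounds, so the three cannot be ranked. The next compound to be tested is compound 4 `Nc1ccccc1NC(=O)/C=C/c1ccc(CSc2cccc3ccccc23)cc1`, which keeps the shared core and changes one group. The change is naphthalen-1-yl in place of 4-fluorophenyl on a sulfur.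

Three measured steps exchange the group at this same place: a number 3.5 percentage points higher from compound 1 to compound 2 (within the scatter), a number 9.7 percentage points higher from compound 1 to compound 3 (within the scatter) and a number 6.2 percentage points higher from compound 2 to compound 3 (within the scatter). Swapping this group has therefore not yet moved the read-out measurably in this assay. Going by the values given here, none of the measured compounds carries naphthalen-1-yl, however, so these steps offer only limited guidance and the range must stay wide.

On this evidence, no step beyond the scatter is expected, and the expected change is a number 3.3 percentage points lower from compound 3 to compound 4 (within the scatter) in size and direction. For compound 4 the estimated value is 15%, with an expected range from 4% to 30%.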

Compound 4, percent growth inhibition at one concentration: 3.7%
For compound 4 the middle estimate is 11.3 percentage points above the measured one; the measured number lies below the stated range.
By their numbers in this assay, from the lowest: compounds 4, 1, 2 and 3 (each within the scatter of the next, the first and the last beyond it).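

In this assay, this place on the sulfur gives its first step beyond the scatter when naphthalen-1-yl, with 2 six-membered aromatic rings of carbon only, replaces 4-fluorophenyl, with one such ring (a number 14.6 percentage points lower from compound 3 to compound 4 (beyond the scatter)). Going by these compounds alone, the other two comparisons stay within the scatter (a number 8.4 percentage points lower from compound 2 to compound 4 (within the scatter); a number 4.9 percentage points lower from compound 1 to compound 4 (within the scatter)), so naphthalen-1-yl is set apart from 4-fluorophenyl but not from 5-(trifluoromethyl)pyridin-2-yl or 3-fluorophenyl, and the step alone shows only that exchanging these two groups can change the read-out measurably. No separate measurement is available to explain this step.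

From the compounds shown here alone, every group on the sulfur so far is an aromatic ring, so what a saturated ring such as cyclohexyl, a longer carbon chain, an amine or a carboxylic acid would give at this place remains open. Going by these compounds, with a single concentration behind each number, it also remains open whether the step between 4-fluorophenyl and naphthalen-1-yl would persist at other concentrations, or in cells other than those of this assay.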